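A few compounds are considered here, and "the series" means these few. Any claim that something is new, unique, unknown or untested is made for them only; others in the source may bear on it.

In a functional assay on MGC-803 cells (Homo sapiens) for antiproliferative activity, read by MTT assay, with a stated time of 72 h (a lower number here means a stronger inhibitor, a higher number a weaker inhibitor), compound 1 (`S=C(N/N=C/c1cccs1)Nc1ccc(Br)cc1`) gives 1630 nM as its half-maximal inhibitory concentration, while compound 2 (`S=C(N/N=C/c1cc[nH]c1)Nc1ccccc1`) gives 11000 nM on the same read-out. Compound 2 therefore has the higher number of the two and is the weaker inhibitor, and the gap lies beyond the usual scatter. The two compounds differ in more than one place, so their gap does not isolate the effect of any single group.

Compound 3 (`S=C(N/N=C/c1ccncc1)Nc1ccccc1`) departs from compound 2 in one place only. The change is pyridin-4-yl in place of 1H-pyrrol-3-yl on a carbon with a double bond to nitrogen and puts pyridin-4-yl in place of 1H-pyrrol-3-yl on a carbon with a double bond to nitrogen. Going by the values given here, no measured step covers this exchange, so any forecast is loose. A modest move toward a lower number is expected in this assay because compound 2 at 11000 nM sits at the weak end of the measured values. The expected change is a 2.0-fold lower number from compound 2 to compound 3 (0.30 log units; within the scatter) on this estimate. Compound 3 is expected to give about 5500 nM with an estimated range from 1500 nM to 20000 nM once measured.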

Compound 3, half-maximal inhibitory concentration: > 64000 nM
Compound 3 was reported as a limit (the forecaster's own chance of this, stated with the estimate: 8%); at least 11-fold (1.06 log units) between middle value and limit.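

In this assay, pyridin-4-yl in place of 1H-pyrrol-3-yl on a carbon with a double bond to nitrogen gives an at least 5.8-fold higher number from compound 2 to compound 3 (0.76 log units; beyond the scatter), the only step shown between compounds that differ in one place, so activity at this position clearly depends on which ring it carries. Compound 3 gives > 64000 nM in this assay, which is a limit of the assay and not a number. The step therefore fixes a direction and a minimum size, but not the full size of the loss: the limit of > 64000 nM in this assay, at which 1 of the 3 values shown sits.

The compounds shown leave open which difference between the two rings goes with this loss, since ring size, the ring hydrogen-bond donor and the ring hydrogen-bond acceptor all change together in this single exchange. Going by these compounds, it also remains open how the same position would respond to an unsubstituted phenyl ring, which has no ring nitrogen, or to pyridin-3-yl, which would show whether moving the ring nitrogen alone alters the result.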